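Ester-to-hydroxyl step in a nitrophenyl cyclohexanecarboxamide series

This account rests on a few compounds, and the source may have more. Where it says the series, first, only, none or still open, it means among the compounds named here.

Measured so far:
Compound 1, `O=C(OC1(C(=O)Nc2ccc([N+](=O)[O-])cc2)CCCCC1)c1ccc(Br)cc1`: 523 nM
Compound 2, `O=C(OC1(C(=O)Nc2ccc([N+](=O)[O-])cc2)CCCCC1)c1ccccc1`: 246 nM
Compound 3, `CC(=O)OC1(C(=O)Nc2ccc([N+](=O)[O-])cc2)CCCCC1`: 386 nM

All three were read in an ADME assay on WI-38 cells (Homo sapiens) for inhibition, read by MTT assay, with a stated time of 72 h; a higher number here means a weaker inhibitor, a lower number a stronger inhibitor. Compound 3 stands second highest of the three numbers; its nearest neighbour is compound 1, and from compound 1 to compound 3 the number moves by a 1.4-fold lower number from compound 1 to compound 3 (0.13 log units; within the scatter), while from compound 2 to compound 3 it moves by a 1.6-fold higher number from compound 2 to compound 3 (0.20 log units; within the scatter). Both of those steps stay within the scatter, so the three ester groups tried so far are not separated by the data. Going by the values given here, the only step beyond the scatter is a 2.1-fold lower number from compound 1 to compound 2 (0.33 log units; beyond the scatter), on the aromatic ring of the ester and not on the carbonyl carbon.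

Compound 4, `O=C(Nc1ccc([N+](=O)[O-])cc1)C1(O)CCCCC1`, has not yet been measured. It differs from compound 3 by hydrogen in place of acetyl on an oxygen on a saturated carbon: the ester is gone altogether and a free hydroxyl remains. Among the compounds with values here, no measured pair removes the ester, so the steps from compound 1 to compound 3 and from compound 2 to compound 3 are the closest guide; they show that swapping one acyl group for another changes little. A step of roughly a 1.6-fold higher number from compound 3 to compound 4 (0.19 log units; within the scatter) is expected, most likely no further than the scatter. The range is wide: the change reaches beyond what has been tried. Compound 4 is therefore estimated at 600 nM, between 200 nM and 2000 nM.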

Compound 4, half-maximal inhibitory concentration: 1220 nM
Compound 4: middle estimate off by 2.0-fold (0.31 log units), on the low side, and the stated range covers the measured number.
By their numbers in this assay, from the lowest: compounds 2, 3 and 1 (each within the scatter of the next, the first and the last beyond it); then compound 4.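

Within this assay, replacing the acyl group on this oxygen with hydrogen gives a 3.2-fold higher number from compound 3 to compound 4 (0.50 log units; beyond the scatter) and a 5.0-fold higher number from compound 2 to compound 4 (0.70 log units; beyond the scatter) and also a 2.3-fold higher number from compound 1 to compound 4 (0.37 log units; beyond the scatter) with each step beyond the scatter, which makes compound 4 the weakest inhibitor of the four. The position therefore responds to losing the ester far more clearly than to the exchange of acetyl for benzoyl or (4-bromophenyl)carbonyl, although the gap from compound 1 to compound 2 shows that the choice of acyl group is not wholly silent. No supporting data bear on why the free hydroxyl gives the higher number.

On these data alone, it remains open whether an acyl carbonyl is required at this oxygen or whether any group capping it would restore the lower numbers, a question that a methyl ether or a carbamate at the same place could address. It is also unknown how an amine in place of the hydroxyl, or a longer acyl chain than acetyl, would sit relative to compound 3 and compound 4 in this series.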